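Compound 4 Expected to Stay Beyond the Cytotoxicity Limit

A few compounds are considered here, and "the series" means these few. Any claim that something is new, unique, unknown or untested is made for them only; others in the source may bear on it.

Compound 1 `OB1OCc2ccc(-n3ccc4ccccc43)cc21` gives > 10 ug/mL in an ADME assay on L929 cells (Mus musculus) for cytotoxicity, read by resazurin assay, with a stated time of 72 h (a higher number here means a weaker inhibitor, a lower number a stronger inhibitor), which is a limit of the assay rather than a number.
Compound 2 `OB1OCc2ccc(-n3cc(Sc4ccccc4O)c4ccccc43)cc21` gives > 10 ug/mL in this assay, again a limit.
Compound 3 `CC(=O)c1ccn(-c2ccc3c(c2)B(O)OC3)c1` gives > 10 ug/mL in this assay, also a limit.

Compound 3 therefore stands at the limit of > 10 ug/mL in this assay, at which 3 of the 3 values shown sit, so its true value is not known, only that it lies beyond the limit. Compound 4 `Nc1ccc(C(=O)c2ccn(-c3ccc4c(c3)B(O)OC4)c2)cc1` differs from compound 3 by a single change: 4-aminophenyl in place of methyl on a carbonyl carbon. Among the compounds with values here, the only measured step, a step that the two limits leave unreadable from compound 1 to compound 2, concerns a different change and cannot be read because both ends are limits; no measured step bears directly on the change from compound 3 to compound 4. With every measured value at the limit, compound 4 is expected to sit at the limit as well, so the step that the limit leaves unreadable from compound 3 to compound 4 is estimated to be none beyond the scatter. Compound 4 is estimated at 15 ug/mL, within a range from 5 ug/mL to 50 ug/mL.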

Compound 4, half-maximal inhibitory concentration: 3.9 ug/mL
The estimate for compound 4 lay 3.8-fold (0.59 log units) above the measured number, outside the stated range (below it).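

In this assay, the carbonyl carbon proves sensitive to what it carries: 4-aminophenyl in place of methyl gives an at least 2.5-fold lower number from compound 3 to compound 4 (0.40 log units; beyond the scatter). The earlier compounds shown here could not show such a shift, and the step from compound 1 to compound 2 cannot be read, as both of its ends are limits. Compound 4 is therefore the first compound here to give a readable number rather than a limit, and the true size of its step stays unknown, as the other end is a limit, in a set where most values look alike: the limit of > 10 ug/mL in this assay, at which 3 of the 4 values shown sit.

As far as these compounds go, what stays open is whether the aromatic ring or its amine drives the change. A plain phenyl on the same carbonyl carbon, or a short chain ending in an amine, would tell these two parts apart.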